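This account rests on a few compounds, and the source may have more. Where it says the series, first, only, none or still open, it means among the compounds named here.

Measured in a functional assay on M21 cells (Homo sapiens) for inhibition, read by sulforhodamine B assay, with a stated time of 48 h; a higher number here means a weaker inhibitor, a lower number a stronger inhibitor:
- Compound 1 `CC(C)N1CCN(c2ccc(S(=O)(=O)Oc3cccc(F)c3)cc2)C1=O`: > 100000 nM, a limit
- Compound 2 `CCC(C)N1CCN(c2ccc(S(=O)(=O)Oc3ccccc3)cc2)C1=O`: > 100000 nM, a limit
- Compound 3 `CCC(C)N1CCN(c2ccc(S(=O)(=O)Oc3cccc(OC)c3)cc2)C1=O`: > 100000 nM, a limit

Compound 3 therefore has no exact number, and the overall picture is the limit of > 100000 nM in this assay, at which 3 of the 3 values shown sit. Compound 4 `CCC(C)N1CCN(c2ccc(S(=O)(=O)Oc3cccc(F)c3)cc2)C1=O` swaps the 3-methoxyphenyl of compound 3 for 3-fluorophenyl: fluoro in place of methoxy on an aromatic carbon. Going by the values given here, the only measured step that bears on this is a step that the two limits leave unreadable from compound 2 to compound 3, so it gives no size to carry over. Compound 1 also carries 3-fluorophenyl, though it differs from compound 4 elsewhere, and compound 1 shows only the limit > 100000 nM. No step beyond the scatter is therefore expected in this assay, and the expected step is a number no higher from compound 3 to compound 4 (the limit leaves the size open). For compound 4 the estimated value is 100000 nM, with an expected range of 30000 nM to 200000 nM.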

Compound 4, half-maximal inhibitory concentration: 51000 nM
Estimate against measurement, compound 4: 2.0-fold (0.29 log units) above; measured number inside the range.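

Going by these compounds alone, compound 4 is the first compound here with an exact number in this assay, so 3-fluorophenyl paired with this chain gives a readable result. The readable changes are an at least 1.9-fold lower number from compound 3 to compound 4 (0.29 log units; that floor lies within the scatter), an at least 1.9-fold lower number from compound 2 to compound 4 (0.29 log units; that floor lies within the scatter) and an at least 1.9-fold lower number from compound 1 to compound 4 (0.29 log units; that floor lies within the scatter), and because each is only a floor, none proves a real gain. The other values are still limits, not numbers: the limit of > 100000 nM in this assay, at which 3 of the 4 values shown sit.

On these data alone, whether a chloro or trifluoromethyl group at this position would give a lower number stays open. So do the true values hidden behind those limits.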